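The compounds below may be only part of what the source reports. "The series", "measured", "known", "first", "only" and "open" are said of these compounds alone.

Working notes on the series.

The shared core is the sulfonamide of compound 1 `CC(C)(C)c1ccc(S(=O)(=O)Nc2ccc(Cl)cc2-c2ncncc2N)cc1`, which in a functional assay on isolated protein for antagonist activity at C-C chemokine receptor type 9 (Homo sapiens), read by calcium flux, with a stated time of 10 min (a higher number here means a weaker inhibitor, a lower number a stronger inhibitor), gives 3.2 nM. Compound 2 `CNc1ncc(O)c(-c2cc(Cl)ccc2NS(=O)(=O)c2ccc(C(C)(C)C)cc2)n1` gives 27 nM and compound 3 `CC(C)(C)c1ccc(S(=O)(=O)Nc2ccc(Cl)cc2-c2ncnc(CO)c2O)cc1` gives 11 nM in this assay . Compound 3 therefore stands second highest of the three numbers: the step of a 2.5-fold lower number from compound 2 to compound 3 (0.39 log units; beyond the scatter) is beyond the scatter, as is the step of a 3.4-fold higher number from compound 1 to compound 3 (0.54 log units; beyond the scatter), so compound 3 sits between compound 2 and compound 1.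

Compound 4 `CNc1nccnc1-c1cc(Cl)ccc1NS(=O)(=O)c1ccc(C(C)(C)C)cc1` is compound 3 with a group of 8 heavy atoms (5 carbon, 3 nitrogen; one six-membered aromatic ring with 2 hetero atoms) in place of a group of 9 heavy atoms (5 carbon, 2 nitrogen, 2 oxygen; one six-membered aromatic ring with 2 hetero atoms), on an aromatic carbon, the entering group being 3-(methylamino)pyrazin-2-yl. Within the data shown here, no measured step matches this change directly. The step of a 3.4-fold higher number from compound 1 to compound 3 (0.54 log units; beyond the scatter) shows that the ring bearing two oxygens gave a higher number than the plain amino diazine of compound 1, and the step of an 8.4-fold higher number from compound 1 to compound 2 (0.93 log units; beyond the scatter) shows that a methylamino ring with one oxygen also gave a higher number. Compound 4 removes both oxygens, so a lower number than compound 3 is expected, of about a 2.2-fold lower number from compound 3 to compound 4 (0.34 log units; beyond the scatter), falling short of compound 1. Compound 4 is therefore estimated at 5 nM in this assay , with a range from 2 nM to 15 nM.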

Compound 4, half-maximal inhibitory concentration: 25 nM
Compound 4: middle estimate off by 5.0-fold (0.70 log units), on the low side; the whole stated range lies below it.
By their numbers in this assay, from the lowest: compound 1; then compound 3; then compounds 4 and 2 (each within the scatter of the next).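

Taking out both oxygens did not lower the number at this position, ortho to a large group: in this assay the change gives a 2.3-fold higher number from compound 3 to compound 4 (0.36 log units; beyond the scatter). With a 1.1-fold lower number from compound 2 to compound 4 (0.03 log units; within the scatter), the 3-(methylamino)pyrazin-2-yl group of compound 4 cannot be told apart from the methylamino ring with one oxygen of compound 2. The gap to the plain amino ring remains, at a 7.8-fold higher number from compound 1 to compound 4 (0.89 log units; beyond the scatter), so the higher numbers of this set do not depend on an oxygen in the ring, and no measurement at hand gives a reason for these steps.

Open, on these data alone, is how this assay would read with a plain amine in place of the methylamino group of compound 4. Also open, as far as these compounds go, is the effect of a longer chain on that nitrogen, such as ethylamino.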